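Swapping the Ring on a Thiocarbonyl Carbon

This account rests on a few compounds, and the source may have more. Where it says the series, first, only, none or still open, it means among the compounds named here.

Compound 2 `O=C(/C=C/c1ccc(Cl)cc1)c1ccc(OCCSC(=S)N2CCOCC2)cc1` is one of two compounds with a result in a functional assay on ECa-109 cells for inhibition, with ECa-109 cell line (Homo sapiens) as the target, read by MTT assay, with a stated time of 72 h; on this read-out higher numbers stand for weaker inhibition and lower numbers for stronger inhibition. In this assay compound 2 gives 15400 nM. Compound 1 `O=C(/C=C/c1cccs1)c1ccc(OCCSC(=S)N2CCCC2)cc1` gives 18300 nM in this assay; compound 2 stands at the lower of the two numbers, but the gap between them is within the usual scatter of repeated measurements, so the two cannot be separated. Compound 3 `O=C(/C=C/c1ccc(Cl)cc1)c1ccc(OCCSC(=S)N2CCCC2)cc1` has not yet been measured. It differs from compound 2 in one place: pyrrolidin-1-yl in place of morpholin-4-yl on a thiocarbonyl carbon. For the measured compounds named here, no pair of measured compounds differs only in this way, so there is no directly comparable step to draw on. Compound 1 already carries pyrrolidin-1-yl on its thiocarbonyl carbon and gives 18300 nM, a number that sits within the scatter of compound 2. For that reason the step from compound 2 to compound 3 is expected to be small, a 1.0-fold lower number from compound 2 to compound 3 (0.01 log units; within the scatter), with no direction beyond the scatter. Compound 3 is therefore estimated at 15000 nM in this assay, with a range from 7000 nM to 35000 nM.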

Compound 3, half-maximal inhibitory concentration: 27800 nM
Compound 3: the middle estimate sits 1.9-fold (0.27 log units) below what was measured; measured number inside the range.
By their numbers in this assay, from the lowest: compounds 2, 1 and 3 (each within the scatter of the next).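

In this assay the swap on a thiocarbonyl carbon can now be read directly as a 1.8-fold higher number from compound 2 to compound 3 (0.26 log units; within the scatter) and this lies within the scatter, so replacing morpholin-4-yl, a six-membered non-aromatic ring with 2 hetero atoms, by pyrrolidin-1-yl, a five-membered one with 1 hetero atom, cannot be told apart from no effect at this position. The other new comparison, a 1.5-fold higher number from compound 1 to compound 3 (0.18 log units; within the scatter) for 4-chlorophenyl in place of thiophen-2-yl on a double-bonded chain carbon bound to a double-bonded chain carbon, also lies within the scatter, so neither place has yet shown a difference that repeated measurements could separate. No measurement here helps to explain these numbers.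

Still open, going by these compounds, is whether a quite different group on the thiocarbonyl carbon, such as open-chain diethylamino or piperazin-1-yl with its free amine, would give a step beyond the scatter. The same question stands for the other place, where a pyridine ring or an unsubstituted phenyl could take the position of 4-chlorophenyl.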